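The source may report more compounds than this note shows. Statements on the series, on what has been measured and on what is new or still open speak of the compounds shown alone.

Compound 1 `CC(O)(C(=O)Nc1ccc(S(=O)(=O)c2ccccc2)c(O)c1)C(F)(F)F` carries a hydroxy on the ring that bears the amide nitrogen, and in a functional assay (Cavia porcellus) with sulfonylurea receptors; K-ATP channels (Homo sapiens) as the target (on this read-out higher numbers stand for weaker inhibition and lower numbers for stronger inhibition), compound 1 gives 430 nM. Among the compounds that returned a number, compound 1 stands lowest. Compound 2 `CC(O)(C(=O)Nc1ccc(S(=O)(=O)c2cccc(O)c2)cc1)C(F)(F)F` gives 18000 nM in this assay. Compound 3 `Cc1ccc(S(=O)(=O)c2ccc(NC(=O)C(C)(O)C(F)(F)F)cc2)cc1` reaches only the limit of this assay, > 30000 nM. Among the compounds with values here, the one measured step, an at least 1.6-fold higher number from compound 2 to compound 3 (0.22 log units; that floor lies within the scatter), changes the ring attached to the sulfonyl sulfur, so it does not touch the position that is changed here and gives little guidance. Compound 4 `CC(O)(C(=O)Nc1ccc(S(=O)(=O)c2ccccc2)c([N+](=O)[O-])c1)C(F)(F)F` differs from compound 1 by nitro in place of hydroxy on an aromatic carbon. Within the data shown here, with no measured step at this position, the expectation rests on the loss of the hydroxy alone, and compound 4 is expected to give a higher number, a 4.7-fold higher number from compound 1 to compound 4 (0.67 log units; beyond the scatter). The estimate for compound 4 is 2000 nM, with a range from 400 nM to 15000 nM, and a limit rather than a number cannot be ruled out.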

Compound 4, half-maximal inhibitory concentration: > 30000 nM
Compound 4: no number, only a limit (the forecaster's own chance of this, stated with the estimate: 10%); at least 15-fold (1.17 log units) between middle value and limit.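

Nitro in place of hydroxy gives an at least 69-fold higher number from compound 1 to compound 4 (1.84 log units; beyond the scatter) in this assay, so this position, which the earlier step on the ring attached to the sulfonyl sulfur did not touch, is sensitive to change. Within the data shown here, the step is large and beyond the usual scatter, and it is the first measured change at this position. Compound 4 gives a limit rather than a number, so the step has a floor but no known full size: the limit of > 30000 nM in this assay, at which 2 of the 4 values shown sit.

Nitro differs from hydroxy in both heavy atoms and hydrogen-bond donors, and this single step cannot separate the two. The compounds shown also leave open how an amine or a methoxy group at this position would compare with the hydroxy of compound 1.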